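Extending a Sulfur-Linked Chain: From Compound 3 to Compound 4

The source may report more compounds than this note shows. Statements on the series, on what has been measured and on what is new or still open speak of the compounds shown alone.

Measured so far in a functional assay on the whole organism for activation, with Mus musculus as the target; on this read-out lower numbers stand for an effect already at smaller amounts and higher numbers for an effect only at larger amounts of compound:
compound 1 `Nc1ncnc2c1nc(O)n2Cc1ccc(Cl)cc1` gives 30 mg/kg
compound 2 `CCCCOc1nc(N)c2[nH]c(=O)n(Cc3ccccc3)c2n1` gives 0.1 mg/kg
compound 3 `CCSc1nc(N)c2nc(O)n(Cc3ccccc3)c2n1` gives 0.1 mg/kg

Among these three, compound 3 stands level with compound 2 at the digits recorded, the two of them together at the lowest numbers in this assay, while compound 1 lies far higher, beyond the scatter. Compound 4 `CCCCSc1nc(N)c2nc(O)n(Cc3ccccc3)c2n1` has not yet been measured. It differs from compound 3 in one place: ethyl in place of hydrogen on a saturated chain carbon, two bonds along the chain from a sulfur. Among the measured compounds shown here, no two measured compounds differ in only one place, so no step of this kind has yet been seen. Because compound 2, which gives 0.1 mg/kg, sits level with compound 3, the account expects the change to bring a step of no change at the digits printed from compound 3 to compound 4 (within the scatter) in this assay, that is, none beyond the scatter. Compound 4 is therefore estimated at 0.1 mg/kg, within a range from 0.03 mg/kg to 0.3 mg/kg.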

Compound 4, minimum effective dose: 0.3 mg/kg
Compound 4: the middle estimate sits 3.0-fold (0.48 log units) below what was measured, and the stated range covers the measured number.
By their numbers in this assay, from the lowest: compounds 2 and 3 (each within the scatter of the next); then compound 4; then compound 1.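

In this assay the first step seen at this position runs a 3.0-fold higher number from compound 3 to compound 4 (0.48 log units; beyond the scatter), so ethylsulfanyl to butylsulfanyl is not a neutral change here, though the step is only modest. It shows that this saturated chain, two bonds along from the sulfur, responds to added ethyl while the effect remains in place. Nothing measured here accounts for the step. One step defines no trend along the chain. Propylsulfanyl, a longer chain such as hexylsulfanyl, or a chain ending in an amine or a carboxylic acid remains open.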